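Benzyl para substituent: methyl to tert-butyl on the shared core

This account rests on a few compounds, and the source may have more. Where it says the series, first, only, none or still open, it means among the compounds named here.

Of the compounds shown here, three have been measured in a functional assay on NCI-H460 cells (Homo sapiens) for cytotoxicity, read by MTT assay, with a stated time of 72 h; a higher number here means a weaker inhibitor, a lower number a stronger inhibitor. Compound 1 `CCN(CC)Cc1ccc2nc(NC(=O)N/N=C/c3c[nH]c4ccccc34)sc2c1`, which carries hydrogen on the aromatic nitrogen, gives 3140 nM. Compound 3 `CCN(CC)Cc1ccc2nc(NC(=O)N/N=C/c3cn(Cc4ccc(C)cc4)c4ccccc34)sc2c1` gives 320 nM, and the step of a 9.8-fold lower number from compound 1 to compound 3 (0.99 log units; beyond the scatter) is the one clear movement in the set. Compound 2 `Cc1ccc(Cn2cc(/C=N/NC(=O)Nc3nc4ccc(CN(C)C)cc4s3)c3ccccc32)cc1` gives 200 nM, the lowest number of the three, though its distance to compound 3 is within the scatter, so no order between compound 2 and compound 3 can be claimed. The step of a 1.6-fold higher number from compound 2 to compound 3 (0.20 log units; within the scatter) confirms that the amine change on the saturated chain carbon does not move the number beyond the scatter.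

Compound 4 `CN(C)Cc1ccc2nc(NC(=O)N/N=C/c3cn(Cc4ccc(C(C)(C)C)cc4)c4ccccc34)sc2c1` has not yet been measured in this assay. It differs from compound 2 at one place: tert-butyl in place of methyl on an aromatic carbon. Among the compounds with values here, no measured step touches this position, since the only change on the aromatic nitrogen substituent so far is its introduction, seen in the step from compound 1 to compound 3, and the amine step is not related. The expectation is therefore a step within the scatter, a 1.3-fold higher number from compound 2 to compound 4 (0.10 log units; within the scatter), taken as no real change. Compound 4 is estimated at 250 nM in this assay, with a range from 100 nM to 650 nM.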

Compound 4, half-maximal inhibitory concentration: 810 nM
Beside the measured number, compound 4's estimate is 3.2-fold (0.51 log units) below it; the whole stated range lies below it.
By their numbers in this assay, from the lowest: compounds 2 and 3 (each within the scatter of the next); then compound 4; then compound 1.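

In this assay, within the data shown here, the substituent on the benzyl group is not a silent position: 4-(tert-butyl)benzyl in place of 4-methylbenzyl gives a step beyond the scatter (a 4.1-fold higher number from compound 2 to compound 4 (0.61 log units; beyond the scatter)), whereas the earlier steps showed only the effect of introducing 4-methylbenzyl on the aromatic nitrogen (a 9.8-fold lower number from compound 1 to compound 3 (0.99 log units; beyond the scatter)) and a change of amine that stayed within the scatter (a 1.6-fold higher number from compound 2 to compound 3 (0.20 log units; within the scatter)). The change goes from 1 heavy atom to 4 heavy atoms, all carbon, with no ring entering and no change in hydrogen-bond donors, hydrogen-bond acceptors or net charge, so in this single pair the higher number goes with a larger carbon substituent and with no other counted difference. No measurement at hand bears on the reason for this step.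

As far as these compounds go, with only methyl and tert-butyl at this place, it remains open whether the number climbs gradually with the size of an alkyl group or whether tert-butyl alone stands apart, which an ethyl or isopropyl group would help to settle. From the compounds shown here alone, it also remains open whether a methoxy group or a chlorine atom at the same place would behave like methyl or like tert-butyl, and whether the same step holds with diethylamino on the shared core.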